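Methyl to Hydrogen on an Aromatic Oxygen: Two Parallel Steps

This account rests on a few compounds, and the source may have more. Where it says the series, first, only, none or still open, it means among the compounds named here.

Measured compounds:
compound 1 `CCc1cc2cc(OC)cc(C(=O)c3ccc(O)cc3)c2o1`, 60%
compound 2 `CCc1cc2cc(O)cc(C(=O)c3ccc(O)cc3)c2o1`, 41%
compound 3 `CCc1oc2ccc(OC)cc2c1C(=O)c1cc(Br)c(O)c(Br)c1`, 99.9%

In an assay for inhibition of solute carrier family 22 member 12 (Homo sapiens), read by scintillation counting, with a stated time of 60 min, tested at 50 uM (a lower number here means less inhibition, a higher number more inhibition at the concentration tested (going by the name of the read-out)), compound 1 gives 60%. Compound 2 gives 41%. Compound 3 gives 99.9%, the highest of the three. Compound 2 differs from compound 1 by hydrogen in place of methyl on an oxygen on an aromatic ring, and that step is a number 19 percentage points lower from compound 1 to compound 2 (beyond the scatter). The difference between the core of compound 1 and the core of compound 3 is not broken down here.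

Compound 4 `CCc1oc2ccc(O)cc2c1C(=O)c1cc(Br)c(O)c(Br)c1` has not yet been measured in this assay. It differs from compound 3 by hydrogen in place of methyl on an oxygen on an aromatic ring, the same change at the same place. The step is expected to be a number 13.9 percentage points lower from compound 3 to compound 4 (beyond the scatter), resting on a number 19 percentage points lower from compound 1 to compound 2 (beyond the scatter), though it is expected to be smaller because compound 3 gives 99.9% and sits close to the top of the scale. In this assay compound 4 is therefore estimated at 86%, between 65% and 99%.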

Compound 4, a percentage reported as inhibition, at one concentration (the size of the read-out at that concentration, not a potency): 99.9%
Compound 4: the middle estimate sits 13.9 percentage points below what was measured; measured number above the stated range.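

On the core of compound 3, hydrogen in place of methyl on the aromatic oxygen gave no change at the digits printed from compound 3 to compound 4 (within the scatter). In this assay, the change therefore did not carry over at a fixed size from one core to the other: the same change on two cores in this assay, a number 19 percentage points lower (beyond the scatter) from compound 1 to compound 2 and no change at the digits printed (within the scatter) from compound 3 to compound 4, 19 percentage points apart, beyond the scatter of two such steps

Compound 4 gives 99.9%, close to the top of the scale at a single concentration, and whether compound 3 or compound 4 has the stronger effect cannot be read from these numbers; two pairs also establish no general rule for the series.

The compounds shown leave open how either core responds to a longer chain or a carboxylic acid on that aromatic oxygen. They also leave open which structural differences between the two cores separate the two steps.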